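Compound 3 against a single growth-inhibition reading

This account rests on a few compounds, and the source may have more. Where it says the series, first, only, none or still open, it means among the compounds named here.

Measured in an ADME assay on L02 cells (Homo sapiens) for inhibition, read by CCK-8 assay, with a stated time of 48 h; a higher number here means a weaker inhibitor of growth, a lower number a stronger inhibitor of growth:
- compound 1 `CN1CCN(c2ccc(Nc3ncc(Cl)c(NCc4ccc(F)cc4)n3)nc2)CC1`: 39700 nM
- compound 2 `CC(C)c1ccccc1Nc1nc(Nc2ccc(N3CCN(C)CC3)cn2)ncc1Cl`: "not determined" (no result reported)

Going by these compounds, compound 2 has no single number to stand on: its entry in this assay reads "not determined" (no result reported), so its place relative to compound 1 stays open. The next compound to be read is compound 3 `CN1CCN(c2ccc(Nc3ncc(Cl)c(Nc4ccc(C(C)(C)C)cc4)n3)nc2)CC1`. The change is 4-(tert-butyl)phenyl in place of 2-isopropylphenyl on a nitrogen on an aromatic ring, with 4-(tert-butyl)phenyl in place of 2-isopropylphenyl on a nitrogen on an aromatic ring. Among the compounds with values here, no step from compound 2 can be sized, so the only anchor in this assay is compound 1 at 39700 nM. A reading near that anchor is expected, with no step beyond the usual scatter and only a slight lean towards a lower number. For compound 3 the estimated value is 30000 nM, with an expected range of 10000 nM to 70000 nM.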

Compound 3, concentration for 50% growth inhibition: 6070 nM
Beside the measured number, compound 3's estimate is 4.9-fold (0.69 log units) above it, outside the stated range (below it).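

In this assay, putting 4-(tert-butyl)phenyl in place of 4-fluorobenzyl on a nitrogen on an aromatic ring gives a 6.5-fold lower number from compound 1 to compound 3 (0.82 log units; beyond the scatter), so the group at this position can move the growth-inhibition reading beyond the scatter. The step from compound 2 cannot be read, which leaves the exchange of 2-isopropylphenyl for 4-(tert-butyl)phenyl unsized. No measurement at hand bears on the reason for the shift.

Within the data shown here, the single step changes the whole group, so the contribution of the tert-butyl group cannot be separated from that of replacing 4-fluorobenzyl with a phenyl group attached directly to the nitrogen. Also open, going by these compounds, is how this reading would respond to a phenyl group carrying an amine or a carboxylic acid at this position.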